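The source may report more compounds than this note shows. Statements on the series, on what has been measured and on what is new or still open speak of the compounds shown alone.

Measured in an ADME assay on Vero 76 cells (Chlorocebus sabaeus) for cytotoxicity, read by neutral red uptake; on this read-out higher numbers stand for lower toxicity in this test and lower numbers for higher toxicity in this test:
- Compound 1 `CC[C@@H](Nc1nc(SC)nc2c1ccn2[C@H]1[C@H](O)[C@H](O)[C@]2(CO)C[C@H]12)C1CC1`: > 50000 nM, a limit
- Compound 2 `CC(C)C(Nc1nc(Cl)nc2c1ncn2[C@H]1[C@H](O)[C@H](O)[C@]2(CO)C[C@H]12)C(C)C`: > 100000 nM, a limit
- Compound 3 `CC(C)(O)[C@@H](Nc1nc(Cl)nc2c1ccn2[C@H]1[C@H](O)[C@H](O)[C@]2(CO)C[C@H]12)C1CC1`: 63000 nM

Compound 3 is the only one of the three with an actual number, at 63000 nM. Going by the values given here, the other two entries are limits of this assay, so they cannot be ranked against it, and no pair of measured compounds differs in one place only.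

The next compound is compound 4 `OC[C@@]12C[C@@H]1[C@@H](n1ccc3c(NC(C4CCC4)C4CCC4)nc(Cl)nc31)[C@H](O)[C@@H]2O`. It has dicyclobutylmethyl in place of 1-cyclopropyl-2-hydroxy-2-methylpropyl on a nitrogen on an aromatic ring.

Among the compounds with values here, the series offers no measured step for this change, so the expectation rests on the level of the values alone. Compound 3 gives the only numerical anchor at 63000 nM, and no step beyond the scatter is expected in this assay. The expected change is a 1.3-fold lower number from compound 3 to compound 4 (0.10 log units; within the scatter). Its direction is not settled by these data, and a report of compound 4 as a limit only would not be surprising. For compound 4 the estimated half-maximal cytotoxic concentration is 50000 nM, with an expected range of 20000 nM to 100000 nM.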

Compound 4, half-maximal cytotoxic concentration: 86000 nM
Beside the measured number, compound 4's estimate is 1.7-fold (0.24 log units) below it; low and high end bracket the measured number.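

In this assay, going by these compounds alone, dicyclobutylmethyl in place of 1-cyclopropyl-2-hydroxy-2-methylpropyl on a nitrogen on an aromatic ring gives a 1.4-fold higher number from compound 3 to compound 4 (0.14 log units; within the scatter), the first step that can be read at all, and the two values do not separate. At this position, then, a group with 1 hydrogen-bond donor, 1 hydrogen-bond acceptor and one three-membered ring can give way to one with neither donor nor acceptor and 2 four-membered rings, with no change in the read-out beyond the scatter. Nothing at hand bears on a cause for this result.

This is a single pair, so it sets no trend for the position, and it cannot say whether a chain carrying an amine or a carboxylic acid on the same nitrogen would stay in the same range. Also open, from the compounds shown here alone, is whether the same exchange would read alike on the core of compound 1 or the core of compound 2.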